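Amine variation on a shared core: outlook for compound 3

The source may report more compounds than this note shows. Statements on the series, on what has been measured and on what is new or still open speak of the compounds shown alone.

Measured so far:
compound 1, `COc1ccc2cc(C(=O)CCN(C)C)c(=O)oc2c1`, gives 21100 nM in an assay on cells for inhibition of Amine oxidase [flavin-containing] B (Homo sapiens), read by fluorescence, spectrophotometry and Amplex Red, with stated times of 60 min and 30 min; a lower number here means a stronger inhibitor, a higher number a weaker inhibitor
compound 2, `COc1ccc2cc(C(=O)CCN3CCCCC3)c(=O)oc2c1`, gives 20100 nM in this assay

Compound 2 stands at the lower of the two numbers, yet the step of a 1.0-fold lower number from compound 1 to compound 2 (0.02 log units; within the scatter) places the two compounds within the scatter of each other, so no real separation has been shown.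

Compound 3, `COc1ccc2cc(C(=O)CCN3CCCC3)c(=O)oc2c1`, differs from compound 2 by pyrrolidin-1-yl in place of piperidin-1-yl on a saturated chain carbon, two bonds along the chain from a carbonyl carbon. For the measured compounds named here, the only measured step that bears on this change is a 1.0-fold lower number from compound 1 to compound 2 (0.02 log units; within the scatter), where an open-chain amine was exchanged for a ring amine at the same place without any movement beyond the scatter. The change from compound 2 to compound 3 is a smaller one, a ring amine exchanged for a ring amine, so no step beyond the scatter is expected in this assay, meaning a 1.0-fold lower number from compound 2 to compound 3 (0.00 log units; within the scatter). Compound 3 is therefore estimated at 20000 nM, with an expected range of 9000 nM to 45000 nM.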

Compound 3, half-maximal inhibitory concentration: 18100 nM
Compound 3: the middle estimate sits 1.1-fold (0.04 log units) above what was measured, within the range that was stated.
By their numbers in this assay, from the lowest: compounds 3, 2 and 1 (each within the scatter of the next).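

In this assay, the size of the amine ring on a saturated chain carbon, two bonds along the chain from a carbonyl carbon, now has a direct reading: pyrrolidin-1-yl in place of piperidin-1-yl gives a 1.1-fold lower number from compound 2 to compound 3 (0.05 log units; within the scatter) and so does not separate the two rings. Pyrrolidin-1-yl in place of dimethylamino gives a 1.2-fold lower number from compound 1 to compound 3 (0.07 log units; within the scatter) and, like the piperidin-1-yl exchange, does not separate a ring amine from the open-chain amine. No measurement is at hand that could account for this flat reading.

Still open, as far as these compounds go, is whether any group at this place gives a step beyond the scatter. A morpholin-4-yl or 4-methylpiperazin-1-yl ring, or a longer chain between the carbonyl and the amine, would put that to the test.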